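Removing the iodo from compound 2

A few compounds are considered here, and "the series" means these few. Any claim that something is new, unique, unknown or untested is made for them only; others in the source may bear on it.

Measured so far in an ADME assay on MT4 cells (Homo sapiens) for cytotoxicity, read by MTT assay, with a stated time of 5 days (on this read-out higher numbers stand for lower toxicity in this test and lower numbers for higher toxicity in this test), are two compounds:
- Compound 1 `Cc1cc(C)cc(Oc2cc(Nc3ccc(C#N)cc3)[nH]c(=O)c2)c1` gives 46000 nM
- Compound 2 `Cc1cccc(C)c1Oc1cc(Nc2ccc(C#N)cc2)[nH]c(=O)c1I` gives 28000 nM

Compound 2 stands with compound 1 on these numbers: the two values lie within the usual scatter of each other, so neither can be ranked above the other. The next compound, compound 3 `Cc1cccc(C)c1Oc1cc(Nc2ccc(C#N)cc2)[nH]c(=O)c1`, has not yet been measured. It comes from compound 2 by a single change, (hydrogen in place of iodo on an aromatic carbon), which puts hydrogen in place of iodo on an aromatic carbon.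

Among the compounds with values here, no pair of measured compounds differs in one place only, so the data give no direct measure of this change. In this assay a small upward step is expected, one that would probably not pass beyond the scatter. Within the data shown here, the only guide is compound 1, which carries no iodo and gives 46000 nM, although it also differs from compound 3 elsewhere. The expected step is a 1.5-fold higher number from compound 2 to compound 3 (0.18 log units; within the scatter) in this estimate. The estimated value for compound 3 is 42000 nM (expected range 18000 nM to 100000 nM).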

Compound 3, half-maximal cytotoxic concentration: 36000 nM
The estimate for compound 3 lay 1.2-fold (0.07 log units) above the measured number; low and high end bracket the measured number.
By their numbers in this assay, from the lowest: compounds 2, 3 and 1 (each within the scatter of the next).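

Within the data shown here, replacing the iodo with hydrogen gave a 1.3-fold higher number from compound 2 to compound 3 (0.11 log units; within the scatter) in this assay, the first direct reading of a change on this aromatic carbon, two atoms from the ring nitrogen, and it shows that the iodo can leave without a step that passes beyond the scatter. Among these compounds, compound 3 also provides the first single-place comparison of the two dimethylphenyl arrangements: 2,6-dimethylphenyl in place of 3,5-dimethylphenyl on the oxygen gave a 1.3-fold lower number from compound 1 to compound 3 (0.11 log units; within the scatter) in this assay, so this second change also stays within the scatter. No measurement of any other kind bears on either step, and the data offer no explanation for them.

The compounds shown carry only iodo or hydrogen on this aromatic carbon, so what an amine, a carboxylic acid or a longer chain there would do to the number remains open. Among the compounds shown here, they also leave open whether the step for removing the iodo would stay within the scatter with 3,5-dimethylphenyl on the oxygen, since no iodo compound with that group is among them.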